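From a Hydroxyphenyl Chain End to a Trimethoxyphenyl One

This account rests on a few compounds, and the source may have more. Where it says the series, first, only, none or still open, it means among the compounds named here.

Among the compounds with values here, compound 3 `CC(C)C[C@H](N)c1cc(C(F)(F)F)ccc1N1CCN(C(=O)CCc2ccccc2O)CC1` gives 3300 nM in an assay on HEK293 cells for displacement of a labelled ligand from Melanocortin receptor 4 (Homo sapiens) (on this read-out lower numbers stand for stronger inhibition and higher numbers for weaker inhibition), the highest of the three numbers known here. Compound 2 `NC(COCc1ccccc1)c1cc(F)ccc1N1CCN(C(=O)CCc2ccc(Cl)cc2Cl)CC1` gives 1000 nM in this assay, a lower number that lies beyond the scatter. Compound 1 `CCCCC(N)c1cc(C(F)(F)F)ccc1N1CCN(C(=O)CCc2ccc(Cl)cc2Cl)CC1` gives 190 nM in this assay, the lowest of the three and farthest from compound 3, again beyond the scatter. Compound 4 `COc1cc(OC)c(OC)cc1CCC(=O)N1CCN(c2ccc(C(F)(F)F)cc2[C@@H](N)CC(C)C)CC1` has not yet been measured. It differs from compound 3 in one place: 2,4,5-trimethoxyphenyl in place of 2-hydroxyphenyl on a saturated chain carbon, two bonds along the chain from a carbonyl carbon. Within the data shown here, no measured pair shows this exchange, so its effect cannot be read from these data. Compound 1 and compound 2 carry other groups in place of the 2-hydroxyphenyl and both give lower numbers than compound 3, but they also differ elsewhere, so nothing firm follows from that. In this assay compound 4 is expected to give 1500 nM, between 300 nM and 8000 nM. The expected step is a 2.2-fold lower number from compound 3 to compound 4 (0.34 log units; beyond the scatter), a modest move toward a lower number that may not exceed the scatter.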

Compound 4, inhibition constant: 6100 nM
Estimate against measurement, compound 4: 4.1-fold (0.61 log units) below; the measured number falls inside the stated range.
By their numbers in this assay, from the lowest: compound 1; then compound 2; then compounds 3 and 4 (each within the scatter of the next).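

In this assay, within the data shown here, the exchange of 2-hydroxyphenyl for 2,4,5-trimethoxyphenyl gives a 1.8-fold higher number from compound 3 to compound 4 (0.27 log units; within the scatter), the first step that can be read at this position, on a saturated chain carbon, two bonds along the chain from a carbonyl carbon. The entering group has 12 heavy atoms in place of 7, and 0 hydrogen-bond donors in place of 1, yet the two compounds stay within the scatter of each other. Nothing available gives a reason for this result.

Among these compounds, the single exchange alters the hydroxyl group and all three methoxy groups at once, so the part each plays stays open, and a phenyl ring with one methoxy group, or with an amine or a carboxylic acid, would separate them. Compound 1 and compound 2 differ from compound 4 in more than one place, so they cannot settle this.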